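Extending the formyl of compound 1 to a furyl enone

This account rests on a few compounds, and the source may have more. Where it says the series, first, only, none or still open, it means among the compounds named here.

Compound 1 `COc1ccc(-c2cc3ccccc3nc2C=O)cc1` gives in a functional assay on NCI-H1299 cells (Homo sapiens) for antiproliferative activity, read by XTT assay, with a stated time of 72 h (a lower number here means a stronger inhibitor, a higher number a weaker inhibitor), only a limit, > 10000 nM, and so stands at the limit of > 10000 nM in this assay, at which 1 of the 3 values shown sits. Compound 2 `COc1ccc(-c2cc3ccccc3nc2/C=C/C(=O)c2ccc(F)cc2)cc1` gives 820 nM in this assay, and compound 3 `COc1ccc(-c2cc3ccccc3nc2/C=C/C(=O)c2ccc(O)cc2)cc1` gives 8970 nM. Among the measured compounds shown here, the single measured step, an 11-fold higher number from compound 2 to compound 3 (1.04 log units; beyond the scatter), alters the aryl end of the enone and does not touch the change followed here. Compound 4 `COc1ccc(-c2cc3ccccc3nc2/C=C/C(=O)c2ccco2)cc1` carries 2-((furan-2-yl)carbonyl)ethenyl in place of formyl on an aromatic carbon. For the measured compounds named here, compound 2 and compound 3 both return numbers where compound 1 returns a limit, so the extension is expected to lower the number beyond the scatter, with the furan end having no measured counterpart to fix its size. Compound 4 is estimated at 2000 nM, ranging from 500 nM to 8000 nM. The expected step is then an at least 5.0-fold lower number from compound 1 to compound 4 (0.69 log units; beyond the scatter).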

Compound 4, half-maximal inhibitory concentration: 730 nM
Beside the measured number, compound 4's estimate is 2.7-fold (0.44 log units) above it, within the range that was stated.
By their numbers in this assay, from the lowest: compounds 4 and 2 (each within the scatter of the next); then compound 3. At a limit, above all of these: compound 1.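

Compound 1 stands only at a limit in this assay: the limit of > 10000 nM in this assay, at which 1 of the 4 values shown sits. At this position, next to the ring nitrogen, 2-((furan-2-yl)carbonyl)ethenyl in place of formyl gives an at least 13-fold lower number from compound 1 to compound 4 (1.13 log units; beyond the scatter), a bound rather than a full size for the change. At the far end of the enone, furan-2-yl matches 4-fluorophenyl, with a 1.1-fold lower number from compound 2 to compound 4 (0.05 log units; within the scatter), and it differs from 4-hydroxyphenyl, with a 12-fold lower number from compound 3 to compound 4 (1.09 log units; beyond the scatter), so a phenyl ring is not required there.

From the compounds shown here alone, whether an amine or a carboxylic acid at that end holds this level stays open, as does whether the ethenyl double bond is needed at all.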